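The compounds below may be only part of what the source reports. "The series", "measured", "known", "first", "only" and "open" are said of these compounds alone.

Working notes on the series. Compound 1 `Cc1ccc(NC(=S)OCCNC(=O)c2cccnc2)cc1`, compound 2 `O=C(NCCOC(=S)Nc1ccccc1)c1cccnc1` and compound 3 `COc1ccc(NC(=S)OCCNC(=O)C(C)(C)Oc2ccc(Cl)cc2)cc1` share one core and differ in the substituent on the aromatic ring attached to the thiocarbamate nitrogen. In an ADME assay on WI-38 cells (Homo sapiens) for cytotoxicity, read by MTT assay, with a stated time of 48 h (a higher number here means a weaker inhibitor, a lower number a stronger inhibitor), compound 1 gives > 800000 nM, which is a limit of the assay and not a number. In this assay compound 2 likewise gives > 800000 nM, again a limit. In this assay, within the data shown here, compound 3 gives 780000 nM, the only numbered value of the three. Compound 2 therefore stands at the limit, where two of the three values sit, see (the limit of > 800000 nM in this assay, at which 2 of the 3 values shown sit). Among the measured compounds shown here, the single step between measured compounds, a step that the two limits leave unreadable from compound 1 to compound 2, is hydrogen in place of methyl on an aromatic carbon, and its size cannot be read. Compound 4 `O=C(NCCOC(=S)Nc1ccc(F)cc1)c1cccnc1` differs from compound 2 by fluoro in place of hydrogen on an aromatic carbon. For the measured compounds named here, the only step that bears on this change is unreadable, and compound 3 with a different substituent gives a numbered value. For compound 4 the expected step is a number no higher from compound 2 to compound 4 (the limit leaves the size open), nothing beyond the scatter. Compound 4 is estimated at 800000 nM, with a range from 400000 nM to 1600000 nM, most likely reported as a limit again.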

Compound 4, half-maximal inhibitory concentration: > 800000 nM
Compound 4 gave a limit, no number; the forecaster's own chance of this, stated with the estimate: 70%; the middle value sits exactly at the limit.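

In this assay compound 4 gives > 800000 nM, a limit and not a number. No new step can be read among compound 1, compound 2 and compound 4, since all three stand at that limit: the limit of > 800000 nM in this assay, at which 3 of the 4 values shown sit. Going by these compounds, whether hydrogen, methyl and fluoro on the aromatic carbon differ at all in this assay stays open.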